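The source may report more compounds than this note shows. Statements on the series, on what has been measured and on what is new or still open speak of the compounds shown alone.

Of the compounds shown here, two built on a shared core have been measured in a functional assay on MCF7 cells (Homo sapiens) for inhibition, read by colorimetric assay and MTT assay, with a stated time of 72 h; a higher number here means a weaker inhibitor, a lower number a stronger inhibitor. Compound 1 `COc1cc(C(=O)NNC(=S)Nc2csc(-c3ccccc3)c2)cc(OC)c1OC` gives 43000 nM in this assay. Compound 2 `COc1ccc(C(=O)NNC(=S)Nc2csc(-c3ccccc3)c2)cc1` gives 32000 nM in this assay, the lower of the two numbers, yet the gap to compound 1 lies within the scatter, so the two values show no real separation. Compound 3 `COc1ccc(C(=O)NNC(=S)Nc2csc(-c3ccccc3)c2)cc1OC` has not yet been measured; it differs from compound 2 by methoxy in place of hydrogen on an aromatic carbon. Within the data shown here, no step between measured compounds covers this change, so its size cannot be read off directly. Both measured compounds carry methoxy on that ring, and compound 1 at 43000 nM and compound 2 at 32000 nM sit within the scatter of each other, so the step expected from compound 2 to compound 3 in this assay is a 1.1-fold higher number from compound 2 to compound 3 (0.05 log units; within the scatter), none beyond the scatter. Compound 3 is therefore estimated at 36000 nM, with a range from 15000 nM to 85000 nM.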

Compound 3, half-maximal inhibitory concentration: 21000 nM
The estimate for compound 3 lay 1.7-fold (0.23 log units) above the measured number, within the range that was stated.
By their numbers in this assay, from the lowest: compounds 3, 2 and 1 (each within the scatter of the next, the first and the last beyond it).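

In this assay, methoxy in place of hydrogen on the aromatic carbon ortho to a methoxy group and meta to a large group gives a 1.5-fold lower number from compound 2 to compound 3 (0.18 log units; within the scatter), so this single addition does not set compound 3 apart from compound 2. The other new comparison, hydrogen in place of methoxy, gives a 2.0-fold lower number from compound 1 to compound 3 (0.31 log units; beyond the scatter), a modest step and the only one among these compounds that goes beyond the scatter. No measurement given here accounts for either step.

The compounds shown leave open whether a hydroxyl group, a fluorine atom or an amine on this aromatic carbon would give a number clearly apart from that of compound 2. They also leave open whether a longer chain in place of methoxy would carry the number further in either direction.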